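Hydroxyphenyl ring isomers on the shared core: working notes

A few compounds are considered here, and "the series" means these few. Any claim that something is new, unique, unknown or untested is made for them only; others in the source may bear on it.

Measured compounds in a functional assay on HCT-15 cells (Homo sapiens) for inhibition; on this read-out higher numbers stand for weaker inhibition and lower numbers for stronger inhibition:
Compound 1 `Oc1ccccc1-c1cc(-c2cccc(F)c2)cc(-c2ccccc2O)n1` gives > 50000 nM; this is a limit of this assay, not a number.
Compound 2 `Oc1ccc(-c2cc(-c3cccc(F)c3)cc(-c3ccccc3O)n2)cc1` gives > 50000 nM; this is likewise a limit.

Among the measured compounds shown here, compound 2 therefore stands at the limit of this assay, and the only step measured so far, a step that the two limits leave unreadable from compound 1 to compound 2, gives no readable size; both measured values sit at the limit of > 50000 nM in this assay, at which 2 of the 2 values shown sit.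

Compound 3 `Oc1ccc(-c2cc(-c3cccc(F)c3)cc(-c3cccc(O)c3)n2)cc1` differs from compound 2 by 3-hydroxyphenyl in place of 2-hydroxyphenyl on an aromatic carbon. For the measured compounds named here, no measured step reads on this change: the one step seen concerns a different hydroxyphenyl isomer and is itself unreadable. With nothing to suggest a direction, compound 3 is expected to stay at the limit, and the step of a number no higher from compound 2 to compound 3 (the limit leaves the size open) is estimated as none beyond the scatter. For compound 3 the estimate is 50000 nM, in the range 20000 nM to 200000 nM.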

Compound 3, half-maximal inhibitory concentration: 3070 nM
The estimate for compound 3 lay 16-fold (1.21 log units) above the measured number, outside the stated range (below it).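

In this assay, among the compounds shown here, moving from 2-hydroxyphenyl to 3-hydroxyphenyl on the aromatic carbon next to the ring nitrogen gives an at least 16-fold lower number from compound 2 to compound 3 (1.21 log units; beyond the scatter), the first readable step. The two groups have the same atoms, joined differently, so this position distinguishes between hydroxyphenyl isomers, which the unreadable step between the two earlier compounds could not show. Compound 3 also gives the series its first actual number, while the other two compounds remain at a limit: the limit of > 50000 nM in this assay, at which 2 of the 3 values shown sit.

On these data alone, whether an aminophenyl group or a carboxyphenyl group at this position would keep or lose the number found for compound 3 remains open. Also open, as far as these compounds go, is whether the step depends on the 4-hydroxyphenyl and 3-fluorophenyl groups that compound 2 and compound 3 share.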